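The compounds below may be only part of what the source reports. "The series", "measured", "known", "first", "only" and "open" are said of these compounds alone.

For the measured compounds named here, compound 2 `CC(C)CCNC(=O)[C@H](C)NC(=O)C[C@H](O)[C@H](CC(C)C)NC(=O)[C@@H](NCC(=O)C(C)(C)C)C(C)C` gives 7.5 nM in an assay on isolated protein for inhibition of Pepsin A (Sus scrofa) (a lower number here means a stronger inhibitor, a higher number a weaker inhibitor), the lowest of the two numbers measured so far. Going by the values given here, the only other measured compound, compound 1 `CC(C)CCNC(=O)[C@H](C)NC(=O)C[C@H](O)[C@H](CC(C)C)NC(=O)[C@@H](NC(=O)OC(C)(C)C)C(C)C`, gives 170 nM in this assay. The two differ in a single place, and the measured step between them is large: a 23-fold lower number from compound 1 to compound 2 (1.36 log units; beyond the scatter).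

Compound 3 `CC(C)CCNC(=O)[C@H](C)NC(=O)C[C@H](O)[C@H](CC(C)C)NC(=O)[C@@H](NC(=O)OC(C)C)C(C)C` has not yet been measured. It differs from compound 2 at the same position: isopropoxycarbonyl in place of ((tert-butyl)carbonyl)methyl on an amine nitrogen. The group that enters is a carbamate-type group, as is the tert-butoxycarbonyl of compound 1, so compound 3 is in effect a smaller relative of compound 1 rather than of compound 2. Among the compounds with values here, the one measured step that bears on this move is the one from compound 1 to compound 2 a 23-fold lower number from compound 1 to compound 2 (1.36 log units; beyond the scatter), and compound 3 walks most of that path backwards. A rise in the number of roughly comparable size is therefore expected, which means a weaker inhibitor than compound 2. For compound 3 the expected step is a 27-fold higher number from compound 2 to compound 3 (1.43 log units; beyond the scatter), and the estimate is 200 nM, with a range from 50 nM to 800 nM.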

Compound 3, inhibition constant: 8.6 nM
Beside the measured number, compound 3's estimate is 23-fold (1.37 log units) above it; measured number outside the range, below it.
By their numbers in this assay, from the lowest: compounds 2 and 3 (each within the scatter of the next); then compound 1.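

In this assay the exchange of ((tert-butyl)carbonyl)methyl for isopropoxycarbonyl on this amine nitrogen gives a 1.1-fold higher number from compound 2 to compound 3 (0.06 log units; within the scatter), so two groups with different atoms fit this position about equally well, and a carbamate-type group as such does not cost activity here. The large difference seen earlier therefore cannot be read as ketone-type group against carbamate-type group, since the single replacement of a methyl by hydrogen within the carbamate gives a 20-fold lower number from compound 1 to compound 3 (1.30 log units; beyond the scatter), a step about as large as the one that first drew attention to this position. What matters at this position, among these compounds, is thus the exact shape of the end of the carbamate, though nothing measured here explains that sensitivity.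

The compounds shown leave open whether a still smaller carbamate, such as methoxycarbonyl or ethoxycarbonyl, would stay level with compound 3 or fall away. They also leave open whether removing a methyl from the tert-butyl of compound 2, giving an isopropyl ketone, would change the number at all, which would show whether this sensitivity extends beyond the carbamates.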